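Fluoro on the phenyl ring and cytotoxicity in THP-1 cells

The source may hold more compounds than are shown below. What is called first, only, known or untested is meant among the compounds shown, and "the series" means these compounds.

Measured so far:
compound 1, `Fc1ccc(-c2csc(N/N=C/c3ccc(-n4ccnc4)cc3)n2)cc1`, 18.7%
compound 2, `C(=N/Nc1nc(-c2ccccc2)cs1)\c1ccc(-n2cncn2)cc1`, 28.4%

Of the compounds shown here, two have been tested in an ADME assay on THP-1 cells (Homo sapiens) for cytotoxicity, read by MTT assay, tested at 50 ug/mL; a higher number here means more inhibition at the concentration tested (going by the name of the read-out), a lower number less inhibition. Compound 1 with the structure `Fc1ccc(-c2csc(N/N=C/c3ccc(-n4ccnc4)cc3)n2)cc1` gives 18.7% in this assay, and compound 2 with the structure `C(=N/Nc1nc(-c2ccccc2)cs1)\c1ccc(-n2cncn2)cc1` gives 28.4%. Compound 2 stands highest of the two numbers, but its nearest neighbour, compound 1, lies only within the scatter below it, so the two values cannot be told apart. Among the measured compounds shown here, compound 1 and compound 2 differ in more than one place, and no step between them is given.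

The next compound, compound 3 with the structure `Fc1ccc(-c2csc(N/N=C/c3ccc(-n4cncn4)cc3)n2)cc1`, is not yet measured. It differs from compound 2 in one place: fluoro in place of hydrogen on an aromatic carbon. For the measured compounds named here, since no step between measured compounds is known, the size of the step in this assay is open. Given that compound 1, which also carries the fluoro, gives 18.7%, a step from compound 2 to compound 3 of no more than the scatter is expected, in either direction, and the estimated step is a number 4.4 percentage points lower from compound 2 to compound 3 (within the scatter). Compound 3 is accordingly expected to give 24% in this assay, within a range from 12% to 38%.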

Compound 3, a percentage reported as inhibition, at one concentration (the size of the read-out at that concentration, not a potency): 35.9%
Beside the measured number, compound 3's estimate is 11.9 percentage points below it; low and high end bracket the measured number.
By their numbers in this assay, from the lowest: compounds 1, 2 and 3 (each within the scatter of the next, the first and the last beyond it).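

In this assay, the change from phenyl to 4-fluorophenyl, with fluoro para to a large group, gives a number 7.5 percentage points higher from compound 2 to compound 3 (within the scatter), so this position now has its first direct reading, and the fluoro shows no change that can be told from the scatter. The other single change, 1H-1,2,4-triazol-1-yl in place of 1H-imidazol-1-yl on an aromatic carbon with the 4-fluorophenyl held constant, gives a number 17.2 percentage points higher from compound 1 to compound 3 (beyond the scatter), a modest step and the only one of the two that stands clear of the scatter, which places the one readable difference in this set at the azole rather than at the fluoro. No measurement at hand accounts for either step.

As far as these compounds go, the fluoro step is read only with the 1H-1,2,4-triazol-1-yl group in place, so it remains open whether it would be the same with 1H-imidazol-1-yl there. From the compounds shown here alone, it also remains open how a chloro, a methoxy group or an amine at the same place on the phenyl ring would compare with hydrogen and fluoro in this assay.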